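Nitro for Chloro on the Pyridinyl Group of Compound 3

A few compounds are considered here, and "the series" means these few. Any claim that something is new, unique, unknown or untested is made for them only; others in the source may bear on it.

Measured in a functional assay (muscle tissue) with Cavia porcellus as the target; a higher number here means a weaker inhibitor, a lower number a stronger inhibitor:
Compound 1 `CC1=NC(C)=C([N+](=O)[O-])C(c2ncccc2C)/C1=C(/O)OCCc1ccccc1`: 5430 nM
Compound 2 `CC1=NC(C)=C([N+](=O)[O-])C(c2cccc(C(F)(F)F)n2)/C1=C(/O)OCCc1ccccc1`: 1410 nM
Compound 3 `CC1=NC(C)=C([N+](=O)[O-])C(c2cccc(Cl)n2)/C1=C(/O)OCCc1ccccc1`: 1510 nM

Compound 3 stands second highest of the three numbers; its nearest neighbour is compound 2, a 1.1-fold higher number from compound 2 to compound 3 (0.03 log units; within the scatter), and compound 1 lies furthest, a 3.6-fold lower number from compound 1 to compound 3 (0.56 log units; beyond the scatter). Compound 4 `CC1=NC(C)=C([N+](=O)[O-])C(c2cccc([N+](=O)[O-])n2)/C1=C(/O)OCCc1ccccc1` differs from compound 3 by nitro in place of chloro on an aromatic carbon, read one bond further out as 6-chloropyridin-2-yl to 6-nitropyridin-2-yl. For the measured compounds named here, no measured step involves a nitro group. Going by the values given here, the only step at this aromatic carbon, a 1.1-fold higher number from compound 2 to compound 3 (0.03 log units; within the scatter), stayed within the scatter, and the two steps that concern the whole pyridinyl group, a 3.9-fold lower number from compound 1 to compound 2 (0.59 log units; beyond the scatter) and a 3.6-fold lower number from compound 1 to compound 3 (0.56 log units; beyond the scatter), were modest and alike. Compound 4 is therefore expected to show a 1.0-fold lower number from compound 3 to compound 4 (0.00 log units; within the scatter) in this assay, nothing beyond the scatter. The estimate for compound 4 is 1500 nM, with a range from 600 nM to 4000 nM.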

Compound 4, half-maximal inhibitory concentration: 4740 nM
Beside the measured number, compound 4's estimate is 3.2-fold (0.50 log units) below it, outside the stated range (above it).
By their numbers in this assay, from the lowest: compounds 2 and 3 (each within the scatter of the next); then compounds 4 and 1 (each within the scatter of the next).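

Nitro on this aromatic carbon changes the number in this assay, whereas chloro and trifluoromethyl stayed within the scatter of each other, with a 3.1-fold higher number from compound 3 to compound 4 (0.50 log units; beyond the scatter) and a 3.4-fold higher number from compound 2 to compound 4 (0.53 log units; beyond the scatter). The carbon is therefore not indifferent to its substituent, and the lower numbers seen with 6-chloropyridin-2-yl and 6-(trifluoromethyl)pyridin-2-yl do not carry over to 6-nitropyridin-2-yl, which shows a 1.1-fold lower number from compound 1 to compound 4 (0.06 log units; within the scatter). Nothing available explains this difference. The compounds shown leave open how an amine, a nitrile or a methoxy group on this carbon would read in this assay.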